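From methylsulfanyl to pyrrolidin-1-yl on a weakly cytotoxic core

The source may hold more compounds than are shown below. What is called first, only, known or untested is meant among the compounds shown, and "the series" means these compounds.

Among the measured compounds shown here, in a functional assay on SK-MEL-28 cells (Homo sapiens) for cytotoxicity, read by MTT assay, with a stated time of 72 h (a lower number here means a stronger inhibitor, a higher number a weaker inhibitor), compound 1 (`CCOC(=O)c1sc(N2CCCC2)nc1Cl`) gives 82000 nM and is so far the only compound with a true number. Compound 2 (`COC(=O)c1sc2nc(SC)sc2c1C`) reads > 100000 nM in this assay and this is a limit of the assay, not a number. Compound 3 (`COC(=O)c1sc2nc(N3CCCC3)sc2c1C`) keeps the core of compound 2 and has pyrrolidin-1-yl in place of methylsulfanyl on an aromatic carbon. For the measured compounds named here, no measured pair shows this change. Compound 1 carries pyrrolidin-1-yl on a different core and gives 82000 nM as a number, so a modest move toward a stronger inhibitor is expected for compound 3, not a large one. The expected step is an at least 2.2-fold lower number from compound 2 to compound 3 (0.34 log units; beyond the scatter) in this assay and its size stays uncertain with a limit at its start. The estimate for compound 3 is 45000 nM with an expected range from 15000 nM to 100000 nM as its span.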

Compound 3, half-maximal inhibitory concentration: > 100000 nM
Compound 3 was reported as a limit; the forecaster's own chance of this, stated with the estimate: 30%; middle value at least 2.2-fold (0.34 log units) away from the limit.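

No step from compound 2 to compound 3 can be read in this assay, because both values are limits and not numbers: the limit of > 100000 nM in this assay, at which 2 of the 3 values shown sit.

The compounds shown leave open whether pyrrolidin-1-yl in place of methylsulfanyl on an aromatic carbon changes the cytotoxicity on the shared core at all.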